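Compound 3 and a longer piperidine-bearing chain

The source may report more compounds than this note shows. Statements on the series, on what has been measured and on what is new or still open speak of the compounds shown alone.

For the measured compounds named here, in a functional assay on MDA-MB-231 cells (Homo sapiens) for cytotoxicity, read by MTT assay, with a stated time of 72 h (on this read-out lower numbers stand for stronger inhibition and higher numbers for weaker inhibition), compound 3 `O=C1c2c[n+]([O-])c3ccccc3c2C(=O)c2c1c1ccccc1n2CCN1CCCC1` gives 630 nM, the highest number of the three measured so far. Compound 1 `CN(C)CCCCCn1c2c(c3ccccc31)C(=O)c1c[n+]([O-])c3ccccc3c1C2=O` gives 240 nM, and compound 2 `O=C1c2c[n+]([O-])c3ccccc3c2C(=O)c2c1c1ccccc1n2CCCCn1ccnc1` gives 210 nM, two values within the scatter of each other. Compound 4 `O=C1c2c[n+]([O-])c3ccccc3c2C(=O)c2c1c1ccccc1n2CCCCN1CCCCC1` differs from compound 3 by this change: 2-(piperidin-1-yl)ethyl in place of pyrrolidin-1-yl on a saturated chain carbon, two bonds along the chain from an aromatic nitrogen. Going by the values given here, two measured steps bear on it, both modest and beyond the scatter: a 2.6-fold higher number from compound 1 to compound 3 (0.42 log units; beyond the scatter) and a 3.0-fold higher number from compound 2 to compound 3 (0.48 log units; beyond the scatter). Each ends at the 2-(pyrrolidin-1-yl)ethyl chain of compound 3, whereas compound 4 carries a longer chain, so a modest move towards a lower number is expected in this assay. The expected step is a 2.4-fold lower number from compound 3 to compound 4 (0.38 log units; beyond the scatter). The estimate for compound 4 is 260 nM, with an expected range of 110 nM to 600 nM.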

Compound 4, half-maximal inhibitory concentration: 610 nM
Beside the measured number, compound 4's estimate is 2.3-fold (0.37 log units) below it; the measured number lies above the stated range.
By their numbers in this assay, from the lowest: compounds 2 and 1 (each within the scatter of the next); then compounds 4 and 3 (each within the scatter of the next).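

In this assay, the 4-(piperidin-1-yl)butyl chain and the 2-(pyrrolidin-1-yl)ethyl chain cannot be told apart, with a 1.0-fold lower number from compound 3 to compound 4 (0.01 log units; within the scatter). For the compounds shown here, at the place four bonds along the chain from an aromatic nitrogen, piperidin-1-yl instead gives a 2.9-fold higher number from compound 2 to compound 4 (0.46 log units; beyond the scatter) and a 2.5-fold higher number from compound 1 to compound 4 (0.41 log units; beyond the scatter), so a longer chain alone does not accompany the lower numbers of the earlier compounds. No supporting measurement is available to explain this result. The compounds shown leave open how a 4-(pyrrolidin-1-yl)butyl chain or a 2-(piperidin-1-yl)ethyl chain would read, which would separate ring size from chain length. As far as these compounds go, a morpholine at the chain end also remains open.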